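Working notes: an E to Z change on compound 1

The source may hold more compounds than are shown below. What is called first, only, known or untested is meant among the compounds shown, and "the series" means these compounds.

Measured so far in a functional assay on A549 cells (Homo sapiens) for cytotoxicity (on this read-out higher numbers stand for an effect only at larger amounts of compound and lower numbers for an effect already at smaller amounts), on this series
- compound 1 `CCOC(=O)/C=C/C(=O)/C=C/COC(=O)c1ccccc1` gives 36.9 ug/mL
- compound 2 `COC(=O)/C=C/C(=O)CC(O)COC(=O)c1ccccc1` gives 3.28 ug/mL

Compound 1 stands at the higher of the two numbers, and compound 2 lies lower by a gap beyond the usual scatter. These two compounds differ in more than one place, so the gap cannot be read as the size of any single change.

Compound 3 `CCOC(=O)/C=C\C(=O)/C=C/COC(=O)c1ccccc1` has yet to be measured. Its change from compound 1 is the two compounds have the same atoms and bonds and differ only in configuration as drawn: 1 of 2 stereo elements differ; a double bond is drawn E in compound 1 and Z in compound 3 with nothing leaving and nothing entering.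

Going by the values given here, no measured pair differs in one place only, so the data give no direct size for a step of this kind. A small move to a lower number is expected in this assay and probably stays within the scatter, with compound 1 at 36.9 ug/mL as the starting point. The expected move is a 1.7-fold lower number from compound 1 to compound 3 (0.22 log units; within the scatter) and remains an estimate for now. For compound 3 the estimated value is 22 ug/mL with an expected range of 8 ug/mL to 60 ug/mL until the measurement arrives.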

Compound 3, concentration for half-maximal effect: 6.7 ug/mL
For compound 3 the middle estimate is 3.3-fold (0.52 log units) above the measured one; the measured number lies below the stated range.
By their numbers in this assay, from the lowest: compound 2; then compound 3; then compound 1.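

In this assay the series now holds a pair that differs in one place only, and its step is a 5.5-fold lower number from compound 1 to compound 3 (0.74 log units; beyond the scatter). This gives the E to Z change at this double bond a size of its own and shows that it lies beyond the scatter, which the gap between the two earlier compounds could not show, since those differ in more than one place. With nothing leaving and nothing entering, the step can be assigned to the configuration at this double bond alone, because of the following: the fact that compounds 1 and 3 differ only in the configuration as drawn

Going by these compounds, the other double bond is drawn E in both compound 1 and compound 3, so the effect of the same change at that place remains open. On these data alone, the step also rests on a single pair, and whether it keeps its direction and size when the ethyl ester is replaced by a carboxylic acid or an amide stays unknown.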